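The source may hold more compounds than are shown below. What is called first, only, known or untested is meant among the compounds shown, and "the series" means these compounds.

Series notes. For the measured compounds named here, the anchor for this step is compound 2 `Cc1cc2c(c(N)nn2C)c(=O)[nH]1`, which in an assay on isolated protein for inhibition of serine/threonine-protein kinase Chk2 (Homo sapiens), read by mobility shift assay, tested at 30 uM (a lower number here means less inhibition, a higher number more inhibition at the concentration tested (going by the name of the read-out)), gives 3%, the lowest of the three numbers measured so far. Compound 1 `Cc1cc2[nH]nc(N)c2c(=O)[nH]1` gives 27%, and compound 3 `Cn1nc(N)c2c(=O)[nH]c(-c3ccccc3)cc21` gives 16%. Two single-point steps connect them: a number 24 percentage points lower from compound 1 to compound 2 (beyond the scatter), methyl in place of hydrogen on an aromatic nitrogen; and a number 13 percentage points higher from compound 2 to compound 3 (beyond the scatter), phenyl in place of methyl on an aromatic carbon. Both steps are modest.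

Compound 4 `COC(=O)CCc1c(C)[nH]c(=O)c2c(N)nn(C)c12` is the next member to be measured. Compared with compound 2 it carries 2-(methoxycarbonyl)ethyl in place of hydrogen on an aromatic carbon. Going by the values given here, neither measured step involves a 2-(methoxycarbonyl)ethyl group, so nothing bears on it directly; the only step at an aromatic carbon is the phenyl-for-methyl change from compound 2 to compound 3, which moved the number modestly upward. No step beyond the scatter is therefore expected, with a slight upward lean at most. The estimate for compound 4 is 10%, within 0% to 28%. Read as a step, this estimate means a number 7 percentage points higher from compound 2 to compound 4 (within the scatter).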

Compound 4, a percentage reported as inhibition, at one concentration (the size of the read-out at that concentration, not a potency): -1%
The estimate for compound 4 lay 11 percentage points above the measured number, and the stated range ends above it.
By their numbers in this assay, from the lowest: compounds 4 and 2 (each within the scatter of the next); then compound 3; then compound 1.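

In this assay, for the compounds shown here, this is the first reading at the ring carbon ortho to a methyl group, and the 2-(methoxycarbonyl)ethyl chain gives a number 4 percentage points lower from compound 2 to compound 4 (within the scatter), whereas the earlier carbon change, a number 13 percentage points higher from compound 2 to compound 3 (beyond the scatter), replaced the methyl group itself. With compound 2 at only 3%, this result shows no gain in inhibition from the chain at this position, but leaves little room to show a loss. No available evidence bears on this result.

On these data alone, it remains open whether a carboxylic acid or an amine at the end of the chain, or a longer chain, would behave the same way at this position. Also open, as far as these compounds go, is whether the 2-(methoxycarbonyl)ethyl chain would produce a step on the core of compound 1, which starts from 27%.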